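This account rests on a few compounds, and the source may have more. Where it says the series, first, only, none or still open, it means among the compounds named here.

Two stilbene-type compounds of one shared core have been measured in a functional assay on MDA-MB-231 cells (Homo sapiens) for inhibition, read by MTT assay, with a stated time of 48 h; a higher number here means a weaker inhibitor, a lower number a stronger inhibitor. Compound 1 `COc1cc(/C=C/c2ccc(NC(=O)/C=C/c3ccc(Cl)cc3)cc2)cc(OC)c1` gives 14100 nM, while compound 2 `COc1cc(/C=C/c2ccc(OC(=O)/C=C/c3ccc(C(F)(F)F)cc3)cc2)cc(OC)c1` gives 6910 nM, the lower of the two numbers and beyond the usual scatter of compound 1. Compound 3 `COc1cc(/C=C/c2ccc(OC(=O)/C=C/c3ccc(F)cc3)cc2)cc(OC)c1` has not yet been measured; it differs from compound 2 only by fluoro in place of trifluoromethyl on an aromatic carbon. Among the compounds with values here, with no comparable step among the measured compounds, only a small shift, if any beyond the scatter, is expected, amounting to a 1.2-fold higher number from compound 2 to compound 3 (0.09 log units; within the scatter). Compound 3 is therefore estimated at 8500 nM, within a range of 3500 nM to 21000 nM.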

Compound 3, half-maximal inhibitory concentration: 6210 nM
Compound 3: middle estimate off by 1.4-fold (0.14 log units), on the high side, and the stated range covers the measured number.
By their numbers in this assay, from the lowest: compounds 3 and 2 (each within the scatter of the next); then compound 1.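

Replacing trifluoromethyl with fluoro on this aromatic carbon, para to a large group, gives a 1.1-fold lower number from compound 2 to compound 3 (0.05 log units; within the scatter) in this assay. Going from 4 heavy atoms to 1 at this place therefore produces no shift that this assay can distinguish from scatter. No measurement available here explains why these two groups read alike.

On these data alone, whether an amine or a carboxylic acid at this position would read the same remains open. Compound 1 differs from compound 2 in two places, so the effect of its amide link cannot be separated from that of its chloro group.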